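A few compounds are considered here, and "the series" means these few. Any claim that something is new, unique, unknown or untested is made for them only; others in the source may bear on it.

Measured compounds in a functional assay for antagonist activity at transient receptor potential cation channel subfamily V member 1 (Rattus norvegicus), read by FLIPR; on this read-out lower numbers stand for lower potency and higher numbers for higher potency (the scale is a negative logarithm):
compound 1 `O=C(Nc1ccccc1Br)N[C@@H]1CCN(c2cccc(F)c2)C1` — 7.8
compound 2 `Cc1cccc(N2CC[C@H](NC(=O)Nc3ccccc3Br)C2)c1` — the value < 6.8 is a limit of the assay, not a number
compound 3 `O=C(Nc1ccccc1Br)N[C@@H]1CCN(c2ccccn2)C1` — the value < 6.6 is a limit of the assay, not a number

Compound 3 stands at the floor of the numbers shown: for compound 3 this assay gives only a limit, (the limit of < 6.6 in this assay, at which 1 of the 3 values shown sits). Compound 2 likewise sits at a limit, (the limit of < 6.8 in this assay, at which 1 of the 3 values shown sits). Only compound 1 gives a numerical value.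

Going by the values given here, the single step that bears on compound 3 is a number at least 1.20 log units lower from compound 1 to compound 3 (beyond the scatter), a large fall. Compound 4 `Cc1cccc(N2CC[C@@H](NC(=O)Nc3ccccc3Br)C2)c1` is the next compound; the change from compound 3 is 3-methylphenyl in place of pyridin-2-yl on an amine nitrogen in a ring. This reverses the kind of change seen from compound 1 to compound 3, bringing back a carbon-only aromatic ring on the ring nitrogen. A rise in this assay is therefore expected, of about the size of the fall that led to compound 3. For compound 4 the expected value is 7.4, ranging from 6.6 to 8.1, which means an estimated step of a number at least 0.80 log units higher from compound 3 to compound 4 (beyond the scatter). Compound 2, with the other stereochemistry, gives only a limit and does not settle this.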

Compound 4, negative logarithm of the antagonist equilibrium constant: 7.7
Compound 4: middle estimate off by 0.30 log units, on the low side; the range from low to high includes it.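

In this assay, 3-methylphenyl in place of pyridin-2-yl gives a number at least 1.10 log units higher from compound 3 to compound 4 (beyond the scatter), so the fall seen with pyridin-2-yl, a number at least 1.20 log units lower from compound 1 to compound 3 (beyond the scatter), is recovered with a second carbon-only aromatic ring, though compound 2 goes against this as a reading of the ring alone. Methyl and fluoro on the aromatic carbon are not told apart at this position, the step being a number 0.10 log units lower from compound 1 to compound 4 (within the scatter). The configuration at the saturated ring carbon also counts, with a number at least 0.90 log units higher from compound 2 to compound 4 (beyond the scatter) read against the limit of compound 2, and this single pair carries that reading: the fact that compounds 2 and 4 differ only in the configuration as drawn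

Going by these compounds, what a pyridin-3-yl group on the ring nitrogen would do stays open, as does the effect of a trifluoromethyl or methoxy group in place of the methyl. Also open, on these data alone, is whether a chloro group in place of the bromo group would keep these differences.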